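One Added Methyl and Oral Bioavailability

The compounds below may be only part of what the source reports. "The series", "measured", "known", "first", "only" and "open" are said of these compounds alone.

In an in vivo ADME assay on the whole organism for pharmacokinetics, with Rattus norvegicus as the target, at a dose of 5 mg/kg by the oral route (a lower number here means that a smaller share of the oral dose reaches the circulation, a higher number that a larger share of the oral dose reaches the circulation), compound 1 `CCC(CC)[C@@H]1C(=O)N[C@H](C2Cc3ccccc3C2)C(=O)N1[C@@H](C(=O)N1CCOCC1)c1ccc(C)nc1` gives 55%. This is the higher of the two actual numbers available, and it lies beyond the usual scatter from compound 3 `CC[C@H](C)[C@@H]1C(=O)N[C@H](C2Cc3ccccc3C2)C(=O)N1[C@@H](C(=O)NC)c1cnc(C)cc1C`, which gives 11%. Compound 2 `CC[C@H](C)[C@@H]1C(=O)N[C@H](C2Cc3ccccc3C2)C(=O)N1[C@@H](C(=O)N(C)C)c1ccc(C)[n+]([O-])c1` gives < 1%, which is a limit of the assay and not a number.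

Compound 4 `CCC(CC)[C@@H]1C(=O)N[C@H](C2Cc3ccccc3C2)C(=O)N1[C@@H](C(=O)N1CCOCC1)c1ccc(C)nc1C` departs from compound 1 in one place: methyl in place of hydrogen on an aromatic carbon. In words, a methyl replaces a hydrogen on an aromatic carbon, turning 6-methylpyridin-3-yl into 2,6-dimethylpyridin-3-yl. Going by the values given here, no measured pair isolates this change. Compound 1 differs from compound 3 in more than this ring, yet compound 3, at 11%, also bears two methyl groups on its ring, so it offers only a weak hint of a drop. A small downward move, not beyond the scatter, is expected, and the estimated step is a number 8 percentage points lower from compound 1 to compound 4 (within the scatter). Compound 4 is expected to give 47%, with an estimated range from 22% to 70%.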

Compound 4, oral bioavailability: 42%
For compound 4 the middle estimate is 5 percentage points above the measured one, and the stated range covers the measured number.
By their numbers in this assay, from the lowest: compound 3; then compound 4; then compound 1. At a limit, below all of these: compound 2.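

Going by these compounds alone, earlier compounds differed from one another in several places, so only this pair shows what a methyl in place of a hydrogen does at this aromatic carbon, next to the ring nitrogen and ortho to a large group: in this assay, the change gives a number 13 percentage points lower from compound 1 to compound 4 (beyond the scatter). Even so, compound 4 gives 42%, so on this core the carbon accepts a methyl at a modest cost and a sizeable share of the oral dose still reaches the circulation. The compounds shown offer no measurement that explains this step.

Going by these compounds, whether an ethyl group, a chlorine atom or an amine at the same carbon would lower oral bioavailability more or less than methyl remains open. Also open, on these data alone, is whether the same methyl would have a similar effect alongside a dimethylamide in place of the morpholine amide.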